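The source may hold more compounds than are shown below. What is called first, only, known or untested is meant among the compounds shown, and "the series" means these compounds.

Among the measured compounds shown here, compound 2 (`COc1cc(-c2cc(/C=C/C(=O)c3ccc(Cl)c(Cl)c3)[nH]n2)cc(OC)c1OC`) is one of two compounds measured here. In a functional assay on MOLT-4 cells (Homo sapiens) for inhibition, read by sulforhodamine B assay, with a stated time of 48 h (on this read-out higher numbers stand for lower toxicity in this test and lower numbers for higher toxicity in this test), compound 2 gives > 100000 nM, which is a limit of the assay rather than a number. Compound 1 (`COc1cc(-c2cc(/C=C/C(=O)c3ccc(N)cc3)[nH]n2)cc(OC)c1OC`) carries 4-aminophenyl on the carbonyl carbon in place of 3,4-dichlorophenyl; in this assay compound 1 gives > 100000 nM, again a limit. For the measured compounds named here, the single measured step is a step that the two limits leave unreadable from compound 1 to compound 2, so its size is unknown. Compound 3 (`COc1ccc(C(=O)/C=C/c2cc(-c3cc(OC)c(OC)c(OC)c3)n[nH]2)cc1OC`) differs from compound 2 by 3,4-dimethoxyphenyl in place of 3,4-dichlorophenyl on a carbonyl carbon. Going by the values given here, the measured step touches the same place, yet gives no readable size, and the limit of > 100000 nM in this assay, at which 2 of the 2 values shown sit, shows that every value so far sits at the limit. No step beyond the scatter is expected in this assay, and the likeliest outcome for compound 3 is another limit. Compound 3 is therefore estimated at 100000 nM, with a range from 40000 nM to 250000 nM, an expected step of a number no higher from compound 2 to compound 3 (the limit leaves the size open).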

Compound 3, concentration lethal to 50% of the cells: > 100000 nM
Compound 3 was reported as a limit; the forecaster's own chance of this, stated with the estimate: 80%; the middle value lies on the limit itself.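

In this assay, among the compounds shown here, the result for compound 3 is again a limit, so no step from compound 1 or compound 2 to compound 3 can be read: the limit of > 100000 nM in this assay, at which 3 of the 3 values shown sit. The compounds shown leave open whether 4-aminophenyl, 3,4-dichlorophenyl and 3,4-dimethoxyphenyl on the carbonyl carbon differ at all in this read-out.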